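This account rests on a few compounds, and the source may have more. Where it says the series, first, only, none or still open, it means among the compounds named here.

Three compounds of the series have numbers in an ADME assay on HEL cells (Homo sapiens) for cytotoxicity; a lower number here means that less compound is tolerated, a higher number that more compound is tolerated. Compound 1 `C/C(=N\NC(=O)COc1cccc2ccccc12)c1ccc(C#N)cc1Br` gives 12.7 ug/mL, the second highest of the three. Compound 2 `O=C(COc1cccc2ccccc12)N/N=C/c1ccccc1O` gives 3.57 ug/mL, lower than compound 1 by more than the scatter. Compound 3 `COc1cc(/C=N/NC(=O)COc2cccc3ccccc23)cc(OC)c1O` gives 52.8 ug/mL, higher than compound 1 by more than the scatter. Among the measured compounds shown here, no two measured compounds differ in one place only, so no measured step isolates a single change.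

Compound 4 `C/C(=N\NC(=O)COc1cccc2ccccc12)c1ccccc1O` has not yet been measured. Relative to compound 1, it carries 2-hydroxyphenyl in place of 2-bromo-4-cyanophenyl on a carbon with a double bond to nitrogen. For the measured compounds named here, the only measured compound bearing 2-hydroxyphenyl is compound 2 at 3.57 ug/mL, so that number is the main guide, and a single compound is thin support. Compound 4 is therefore expected to sit nearer compound 2 than compound 1 in this assay, with less compound tolerated. The estimated move is a 2.5-fold lower number from compound 1 to compound 4 (0.40 log units; beyond the scatter), a downward step expected to lie modestly beyond the scatter. The estimate for compound 4 is 5 ug/mL, with an expected range from 1.8 ug/mL to 15 ug/mL.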

Compound 4, half-maximal cytotoxic concentration: 4 ug/mL
Beside the measured number, compound 4's estimate is 1.3-fold (0.10 log units) above it, within the range that was stated.
By their numbers in this assay, from the lowest: compounds 2 and 4 (each within the scatter of the next); then compound 1; then compound 3.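

This position on a carbon with a double bond to nitrogen now has its first single-place comparison in this assay: 2-hydroxyphenyl in place of 2-bromo-4-cyanophenyl gives a 3.2-fold lower number from compound 1 to compound 4 (0.50 log units; beyond the scatter), a modest step that shows this aryl group affects how much compound is tolerated. Compound 4 and compound 2 differ only at the other substituent on that carbon, and compound 2 at 3.57 ug/mL and compound 4 at 4 ug/mL lie within the scatter of each other, so this pair shows no separable difference from that substituent while 2-hydroxyphenyl is present. No supporting measurement is available to explain the step from compound 1 to compound 4.

On these data alone, the change removes the bromine and the nitrile and adds the hydroxyl in a single step, so the share of each in the lower number remains open. As far as these compounds go, it is also open whether an amine or a carboxylic acid in place of that hydroxyl would keep the number of compound 4 or move it towards that of compound 1, and how the methoxy and hydroxyl pattern of compound 3 would behave on the same carbon.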